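Swapping the aryl group on the shared core and cytotoxicity

The source may report more compounds than this note shows. Statements on the series, on what has been measured and on what is new or still open speak of the compounds shown alone.

Among the measured compounds shown here, the three compounds measured so far, compound 1 `COc1ccc(-n2c(=O)n(Cc3cc4cc(Cl)ccc4n3CCCC#N)c3cnccc32)cc1`, compound 2 `CC(C)CCn1c(Cn2c(=O)n(C3CC3)c3ccncc32)nc2ccncc21` and compound 3 `CC(C)(C)n1c(=O)n(Cc2cc3cc(Cl)ccc3n2CCCS(C)(=O)=O)c2cnccc21`, were all tested in an ADME assay on HeLa cells (Homo sapiens) for cytotoxicity, read by ATP content, with a stated time of 3 days; on this read-out higher numbers stand for lower toxicity in this test and lower numbers for higher toxicity in this test. In this assay compound 1 gives > 50000 nM, which is a limit of the assay and not a number. Compound 2 likewise reaches only a limit, > 100000 nM. Compound 3 also stops at a limit, > 50000 nM. For the measured compounds named here, compound 1 thus stands together with compound 3 at the limit described by the limit of > 50000 nM in this assay, at which 2 of the 3 values shown sit, while compound 2 sits at the one described by the limit of > 100000 nM in this assay, at which 1 of the 3 values shown sits; none of the three yields a number, so no step between measured compounds can be computed.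

The unmeasured compound 4 `N#CCCCn1c(Cn2c(=O)n(-c3ncco3)c3ccncc32)cc2cc(Cl)ccc21` is derived from compound 1 by a single change: 1,3-oxazol-2-yl in place of 4-methoxyphenyl on an aromatic nitrogen. Since every value shown is a limit, no step is expected beyond the scatter in this assay, and compound 4 is expected to remain at a limit as well. Its estimated value is 50000 nM, with a range from 20000 nM to 100000 nM, which means an expected step of a number no higher from compound 1 to compound 4 (the limit leaves the size open).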

Compound 4, half-maximal cytotoxic concentration: > 50000 nM
Compound 4: no number, only a limit; the forecaster's own chance of this, stated with the estimate: 80%; the middle value sits exactly at the limit.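

In this assay compound 4 gives > 50000 nM, which is a limit of the assay and not a number. Among the compounds shown here, compound 1 also stops at a limit, > 50000 nM, so no step between these two compounds can be read. The compounds shown leave open where any half-maximal cytotoxic concentration actually lies.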